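Methoxy to methyl on the pendant phenyl of compound 2

This account rests on a few compounds, and the source may have more. Where it says the series, first, only, none or still open, it means among the compounds named here.

Measured so far:
Compound 1 `COc1ccc(-c2cc(C)c(Nc3ccnc(Nc4ccc(C#N)cc4)n3)c(C)c2)cc1` — in an ADME assay on MT4 cells (Homo sapiens) for cytotoxicity, read by MTT assay, with a stated time of 4 days (on this read-out lower numbers stand for higher toxicity in this test and higher numbers for lower toxicity in this test), compound 1 gives 2890 nM
Compound 2 `COc1ccccc1-c1cc(C)c(Nc2ccnc(Nc3ccc(C#N)cc3)n2)c(C)c1` — in this assay compound 2 gives 940 nM
Compound 3 `Cc1cc(-c2cc(F)cc(F)c2)cc(C)c1Nc1ccnc(Nc2ccc(C#N)cc2)n1` — in this assay compound 3 gives 3910 nM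

Among these three, compound 2 gives the lowest number in this assay. Its nearest neighbour is compound 1: there was a 3.1-fold lower number from compound 1 to compound 2 (0.49 log units; beyond the scatter). The furthest is compound 3: there was a 4.2-fold higher number from compound 2 to compound 3 (0.62 log units; beyond the scatter). Between compounds 1 and 3 the step was a 1.4-fold higher number from compound 1 to compound 3 (0.13 log units; within the scatter).

Compound 4 `Cc1ccccc1-c1cc(C)c(Nc2ccnc(Nc3ccc(C#N)cc3)n2)c(C)c1` keeps everything of compound 2 except one change: methyl in place of methoxy on an aromatic carbon.

Among the measured compounds shown here, none of the measured steps repeats this change; the two steps beyond the scatter each swapped the whole substitution pattern of the pendant phenyl, whereas here only methoxy gives way to methyl at the same place. A modest step, or none beyond the scatter, is therefore expected in this assay, with a slight lean toward a higher number because compound 2 sits at the low end with 940 nM. The expected step from compound 2 to compound 4 is a 1.5-fold higher number from compound 2 to compound 4 (0.17 log units; within the scatter). Compound 4 is estimated at 1400 nM, within 550 nM to 3500 nM.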

Compound 4, half-maximal cytotoxic concentration: 3820 nM
Compound 4: middle estimate off by 2.7-fold (0.44 log units), on the low side, and the stated range ends below it.
By their numbers in this assay, from the lowest: compound 2; then compounds 1, 4 and 3 (each within the scatter of the next).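

In this assay, replacing methoxy with methyl at this place, ortho to a large group, changes the number beyond the scatter (a 4.1-fold higher number from compound 2 to compound 4 (0.61 log units; beyond the scatter)), so the low number of compound 2 does not follow from just any group standing there. The steps to compound 4 from the other two stay within the scatter (a 1.0-fold lower number from compound 3 to compound 4 (0.01 log units; within the scatter); a 1.3-fold higher number from compound 1 to compound 4 (0.12 log units; within the scatter)), which leaves compound 2 as the only one of the four set apart from the rest. Nothing at hand explains why the 2-methoxyphenyl compound gives the lowest number.

Going by these compounds, it remains open whether an ethoxy, a hydroxyl or an amine at the same place would give a number like that of compound 2 or like that of compound 4. On these data alone, it is also open whether methyl in place of methoxy would change anything in compound 1, where the methoxy stands elsewhere on the pendant phenyl.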